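Shortening the selenium-bound chain of an inactive quinazoline-free scaffold

The source may hold more compounds than are shown below. What is called first, only, known or untested is meant among the compounds shown, and "the series" means these compounds.

Compound 1 (`CCCCC[Se]c1nc(NCc2ccc(SC)cc2)c2ccccc2n1`) was tested in an ADME assay on 184B5 cells (Homo sapiens) for cytotoxicity, read by MTT assay, with a stated time of 72 h; a lower number here means a stronger inhibitor of growth, a higher number a weaker inhibitor of growth. In that test compound 1 gives > 100000 nM, which is a limit of the assay rather than a measured number. Two related compounds were measured alongside it. Compound 2 (`CCCCC[Se]c1nc(NCc2ccccc2)c2ccccc2n1`) gives > 100000 nM in this assay, again only a limit. Compound 3 (`CSc1nc(NCc2ccc([Se]C)cc2)c2ccccc2n1`) likewise gives > 100000 nM, also a limit. Among the measured compounds shown here, the one comparable step, a step that the two limits leave unreadable from compound 1 to compound 2, cannot be read because both of its ends sit at the limit, as the limit of > 100000 nM in this assay, at which 3 of the 3 values shown sit, records for every value so far.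

Compound 4 (`CSc1ccc(CNc2nc([Se]C)nc3ccccc23)cc1`) differs from compound 1 by hydrogen in place of butyl on a saturated chain carbon bound to a selenium atom; cut one bond further out, this reads as pentyl to methyl. For the measured compounds named here, no measured step tracks this change, and every neighbour sits at the limit, so there is no basis for expecting any movement beyond the scatter. The expected step that the limit leaves unreadable from compound 1 to compound 4 is therefore none beyond the scatter. Compound 4 is estimated at 150000 nM, within a range from 50000 nM to 500000 nM, most likely reported again only as a limit.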

Compound 4, concentration for total growth inhibition: > 100000 nM
Compound 4: only a limit was reported; the forecaster's own chance of this, stated with the estimate: 85%; the middle value does not contradict the limit.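

No step can be read between compound 1 and compound 4, because both values are only limits: the limit of > 100000 nM in this assay, at which 4 of the 4 values shown sit.

The compounds shown leave open whether going from pentyl to methyl changes growth inhibition at all in this assay, and what concentration any of them would need.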